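Methoxy in place of bromo: a single-group swap

A few compounds are considered here, and "the series" means these few. Any claim that something is new, unique, unknown or untested is made for them only; others in the source may bear on it.

Three compounds of the shared core have numbers in a functional assay on HCT-116 cells (Homo sapiens) for cytotoxicity, with a stated time of 72 h; on this read-out higher numbers stand for weaker inhibition and lower numbers for stronger inhibition. Compound 1 `C#CCOc1ccc(/C=C/C(=O)c2cccc(Br)c2)cc1OC` gives 1900 nM. Compound 2 `C#CCOc1ccc(/C=C/C(=O)c2ccc(-n3ccnc3)cc2)cc1OC` gives 670 nM, and compound 3 `C#CCOc1ccc(/C=C/C(=O)c2ccc(C(C)C)cc2)cc1CC=C` gives 3130 nM. On these three numbers compound 1 stands second highest: its number and that of compound 3 lie within the scatter of each other, whereas compound 2 gives a number lower than compound 1 by more than the scatter. For the measured compounds named here, no two of the measured compounds differ in one place only, so no single-point step is available from the measured set.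

Compound 4 `C#CCOc1ccc(/C=C/C(=O)c2cccc(OC)c2)cc1OC` has not been measured. It differs from compound 1 as follows: methoxy in place of bromo on an aromatic carbon. Going by the values given here, no measured pair isolates this change, so the expectation for compound 4 rests on compound 1 alone. In this assay the step is expected to be small, plausibly none beyond the scatter, with a slight lean toward a higher number: a 1.3-fold higher number from compound 1 to compound 4 (0.12 log units; within the scatter). Compound 4 is therefore estimated at 2500 nM, within a range of 900 nM to 7000 nM.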

Compound 4, half-maximal inhibitory concentration: 1010 nM
Compound 4: the middle estimate sits 2.5-fold (0.39 log units) above what was measured, and the stated range covers the measured number.
By their numbers in this assay, from the lowest: compounds 2, 4, 1 and 3 (each within the scatter of the next, the first and the last beyond it).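

For the compounds shown here, compound 1 and compound 4 form the only pair that differs in one place, so this is the sole direct reading of a change on this aromatic carbon. In this assay, going from 3-bromophenyl to 3-methoxyphenyl gives a 1.9-fold lower number from compound 1 to compound 4 (0.27 log units; within the scatter), so the bromo and methoxy groups cannot be told apart here, even though methoxy brings an extra heavy atom and a hydrogen-bond acceptor. No measurement available here offers an explanation for this result.

A single step cannot show whether this place accepts groups of a different kind, such as an amine, a carboxylic acid or a longer alkoxy chain. It also leaves open whether methoxy and bromo would remain indistinguishable on a different ring substitution, such as the imidazolyl-bearing ring of compound 2.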